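Working notes: compounds 1 to 4, one binding read-out

A few compounds are considered here, and "the series" means these few. Any claim that something is new, unique, unknown or untested is made for them only; others in the source may bear on it.

All numbers below come from an assay on cells for inhibition of histone deacetylase 4 (Homo sapiens), read by fluorescence, with a stated time of 30 min; a lower number here means a stronger inhibitor, a higher number a weaker inhibitor.
Compound 1, `O=C1NC(=O)/C(=C\c2ccc(OCC(=O)N3N=C(c4ccccc4)CC3c3ccccc3)cc2)S1`: 1600 nM
Compound 2, `O=C1NC(=O)/C(=C\c2ccc(OCC(=O)N3N=C(c4ccccc4)CC3c3ccc(F)cc3)cc2)S1`: 1700 nM
Compound 3, `O=C1NC(=O)/C(=C\c2ccc(OCC(=O)N3N=C(c4ccc(F)cc4)CC3c3ccco3)cc2)S1`: 880 nM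

Compound 3 carries the lowest of the three numbers, but its gaps to compound 1 and to compound 2 both lie within the scatter, so no order among the three is claimed. Compound 4, `O=C1NC(=O)/C(=C\c2ccc(OCC(=O)N3N=C(c4ccc(F)cc4)CC3c3ccc(Cl)c(Cl)c3)cc2)S1`, differs from compound 3 by 3,4-dichlorophenyl in place of furan-2-yl on a saturated ring carbon. For the measured compounds named here, the one measured single-site step, a 1.1-fold higher number from compound 1 to compound 2 (0.03 log units; within the scatter), sits on the same saturated ring carbon but exchanges hydrogen for fluorine and lies within the scatter; no measured step covers a furan-to-dichlorophenyl exchange. The estimate for compound 4 therefore rests on compound 3 alone, and the expected step is a 1.1-fold higher number from compound 3 to compound 4 (0.06 log units; within the scatter), no direction beyond the scatter. In this assay compound 4 is estimated at 1000 nM, within 400 nM to 2500 nM.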

Compound 4, half-maximal inhibitory concentration: 800 nM
Estimate against measurement, compound 4: 1.3-fold (0.10 log units) above; the range from low to high includes it.
By their numbers in this assay, from the lowest: compounds 4, 3, 1 and 2 (each within the scatter of the next, the first and the last beyond it).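

At this saturated ring carbon, the earlier step exchanged only hydrogen for fluorine on the attached phenyl ring, whereas 3,4-dichlorophenyl in place of furan-2-yl exchanges the whole aromatic ring and gives a 1.1-fold lower number from compound 3 to compound 4 (0.04 log units; within the scatter) in this assay. A six-membered carbon ring with two chlorines, without the hydrogen-bond acceptor of furan-2-yl, therefore leaves the number within the scatter. No available evidence accounts for this result.

Every group shown at this carbon is an aromatic ring. As far as these compounds go, how an amine, a carboxylic acid or a longer alkyl chain there would read remains open.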